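This account rests on a few compounds, and the source may have more. Where it says the series, first, only, none or still open, it means among the compounds named here.

Measured so far in an assay on brain (strain Sprague-Dawley) for displacement of a labelled ligand from Translocator protein (Rattus norvegicus), read by scintillation counting, with a stated time of 90 min; on this read-out higher numbers stand for weaker inhibition and lower numbers for stronger inhibition:
Compound 1 `CN(C)C(=O)c1nc2ccccc2c(-c2ccccc2)c1CI` gives 1340 nM.
Compound 2 `O=C(c1nc2ccccc2c(-c2ccccc2)c1CI)N1CCOCC1` gives 27.8 nM.
Compound 3 `O=C(c1cc(-c2ccccc2)c2cc(I)ccc2n1)N1CCOCC1` gives 29900 nM.

On these numbers compound 3 stands highest, that is weakest; its nearest neighbour is compound 1 and its furthest is compound 2. Within the data shown here, the one step measured within the group, a 48-fold lower number from compound 1 to compound 2 (1.68 log units; beyond the scatter), changes the amide, not the halogen, so it says nothing about the move to compound 4 `O=C(c1cc(-c2ccccc2)c2cc(F)ccc2n1)N1CCOCC1`, which is fluoro in place of iodo on an aromatic carbon. Among the measured compounds shown here, no measured pair shows what exchanging one halogen for another on that ring does, so the expectation rests on compound 3 alone. The step from compound 3 to compound 4 is expected to be a 2.0-fold lower number from compound 3 to compound 4 (0.30 log units; within the scatter), a change within the scatter in this assay. Compound 4 is therefore estimated at 15000 nM, with a range from 3000 nM to 60000 nM.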

Compound 4, inhibition constant: 5740 nM
The estimate for compound 4 lay 2.6-fold (0.42 log units) above the measured number, within the range that was stated.
By their numbers in this assay, from the lowest: compound 2; then compound 1; then compound 4; then compound 3.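

Exchanging one halogen for another on this aromatic carbon gives in this assay a 5.2-fold lower number from compound 3 to compound 4 (0.72 log units; beyond the scatter) and is a modest change, yet it lies beyond the usual scatter. This shows that the number responds to which halogen sits at this position, something the earlier step at the amide could not show. No measurement on hand explains this difference.

As far as these compounds go, whether chloro or bromo would fall in order between fluoro and iodo remains open. So does the effect of an amine or a carboxylic acid at this position.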